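The source may hold more compounds than are shown below. What is called first, only, known or untested is meant among the compounds shown, and "the series" means these compounds.

Measured compounds:
compound 1 `Cc1cccc(CSc2cc(Cl)c(C)cc2S(=O)(=O)/N=C(\N)n2nccc2-c2ccccc2)c1`, in a functional assay on HeLa cells (Homo sapiens) for cytotoxicity, read by MTT assay, with a stated time of 72 h (a higher number here means a weaker inhibitor, a lower number a stronger inhibitor), compound 1 gives 8000 nM
compound 2 `Cc1cc(S(=O)(=O)/N=C(\N)n2nccc2-c2ccccc2)c(SCc2ccccc2Cl)cc1Cl`, in this assay compound 2 gives 19000 nM

Among the compounds with values here, compound 1 holds the lowest of the two numbers in this assay, with compound 2 the only neighbour. Compound 3 `Cc1cc(S(=O)(=O)/N=C(\N)n2nccc2-c2ccccc2)c(SCc2ccc(Cl)cc2)cc1Cl` differs from compound 1 by 4-chlorophenyl in place of 3-methylphenyl on a saturated chain carbon bound to a sulfur. Within the data shown here, one measured step bears on this: a 2.4-fold higher number from compound 1 to compound 2 (0.38 log units; beyond the scatter), a modest rise beyond the scatter for a related exchange at the same place. A comparable modest rise in this assay is therefore expected, a 1.5-fold higher number from compound 1 to compound 3 (0.18 log units; within the scatter). Compound 3 is estimated at 12000 nM, with a range from 5000 nM to 30000 nM.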

Compound 3, half-maximal inhibitory concentration: 3000 nM
Beside the measured number, compound 3's estimate is 4.0-fold (0.60 log units) above it, and the stated range ends above it.
By their numbers in this assay, from the lowest: compound 3; then compound 1; then compound 2.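

The exchange to 4-chlorophenyl brings a 2.7-fold lower number from compound 1 to compound 3 (0.43 log units; beyond the scatter) in this assay and so shows that a change at this place can lower the number as well as raise it. The two chlorophenyl groups also differ, with a 6.3-fold lower number from compound 2 to compound 3 (0.80 log units; beyond the scatter) as the chlorine moves from the 2-chlorophenyl to the 4-chlorophenyl arrangement, which leaves compound 3 the strongest of the three. Nothing available here explains this difference. The compounds shown leave open how 3-chlorophenyl or 4-methylphenyl would behave on the saturated chain carbon bound to a sulfur.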